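Chloro for methyl on the aryl ring of compound 3

The source may hold more compounds than are shown below. What is called first, only, known or untested is meant among the compounds shown, and "the series" means these compounds.

Compound 3 `Cc1ccc(-n2cc(C(=O)Nc3cc(F)cc(F)c3)c(=O)c3ccc(N(C)C)nc32)cc1OCCCCCCC[N+]1(C)CCCCC1` stands second highest of the three numbers in an assay on LX2 cells for inhibition of COL1A1 promoter (Homo sapiens), read by a luciferase reporter, with a stated time of 24 h, tested at 50 uM (a higher number here means a stronger effect of the compound at the concentration tested, a lower number a weaker effect), where compound 3 gives 45.1%. Compound 1 `CN(C)c1ccc2c(=O)c(C(=O)Nc3cc(F)cc(F)c3)cn(-c3ccc(Cl)c(OCCCCCCC[N+]45CCN(CC4)CC5)c3)c2n1` gives 18.7% and compound 2 `CN(C)c1ccc2c(=O)c(C(=O)Nc3cc(F)cc(F)c3)cn(-c3ccc(Cl)c(OCCCCCCC[N+]4(C)CCCC4)c3)c2n1` gives 76.1%; both gaps to compound 3 lie beyond the scatter. Within the data shown here, the only single-point step among the measured compounds is a number 57.4 percentage points higher from compound 1 to compound 2 (beyond the scatter), which concerns the charged ring group at the chain end and not the aromatic substituent.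

Compound 4 `CN(C)c1ccc2c(=O)c(C(=O)Nc3cc(F)cc(F)c3)cn(-c3ccc(Cl)c(OCCCCCCC[N+]4(C)CCCCC4)c3)c2n1` is derived from compound 3 by chloro in place of methyl on an aromatic carbon. Among the measured compounds shown here, no measured step covers this change on its own. Compound 2 carries the same chloro group with a five-membered charged ring, while compound 3 carries the methyl with a six-membered charged ring, so the difference between those two values mixes two changes and bears only loosely on the step. Because compound 2 gives 76.1% against compound 3 at 45.1%, a rise is expected, though it could still fall within the scatter. The expected step is a number 14.9 percentage points higher from compound 3 to compound 4 (beyond the scatter), a moderate increase. The estimate for compound 4 in this assay is 60%, with a range from 35% to 85%.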

Compound 4, a percentage reported as inhibition, at one concentration (the size of the read-out at that concentration, not a potency): 90.5%
Estimate against measurement, compound 4: 30.5 percentage points below; measured number above the stated range.
By their numbers in this assay, from the lowest: compound 1; then compound 3; then compound 2; then compound 4.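

In this assay, among these compounds, chloro in place of methyl on the aromatic carbon gives a number 45.4 percentage points higher from compound 3 to compound 4 (beyond the scatter) with the charged ring group at the chain end unchanged, the first reading of this change on its own. With chloro kept, the charged six-membered ring gives a number 14.4 percentage points higher from compound 2 to compound 4 (beyond the scatter) against the five-membered ring group and a number 71.8 percentage points higher from compound 1 to compound 4 (beyond the scatter) against the group with two rings, which puts compound 4 highest of the four, beyond the scatter from each of the others. The read-out in this series therefore depends on the substituent on this aromatic carbon, ortho to a large group and para to a large group, and not only on the charged group at the chain end.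

On these data alone, whether chloro gives a similar gain over methyl when the five-membered charged ring is present remains open, as does how bromo, fluoro or methoxy would read on the same aromatic carbon. All four numbers come from one tested concentration, so they describe the size of the effect at that concentration and give no potency.

No supporting data on this result are available to account for the step.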